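From 3-chloro-2-fluorophenyl to 4-fluorophenyl at the Limit

The compounds below may be only part of what the source reports. "The series", "measured", "known", "first", "only" and "open" are said of these compounds alone.

In a physicochemical assay for pharmacokinetics (on this read-out lower numbers stand for a shorter-lived compound and higher numbers for a longer-lived compound), compound 2 `CCNc1[nH]c(=O)n(O)c(=O)c1C(=O)NCc1cccc(Cl)c1F` gives > 24 h and this is a limit. Compound 1 `CCNc1[nH]c(=O)n(O)c(=O)c1C(=O)NCc1ccccc1` gives > 24 h and this too is a limit. The measured step that the two limits leave unreadable from compound 1 to compound 2 has no readable size, and the limit of > 24 h in this assay, at which 2 of the 2 values shown sit, is all the evidence available. Compound 3 `CCNc1[nH]c(=O)n(O)c(=O)c1C(=O)NCc1ccc(F)cc1` carries 4-fluorophenyl in place of 3-chloro-2-fluorophenyl, and 4-fluorophenyl in place of 3-chloro-2-fluorophenyl on a saturated chain carbon bound to an amide-type nitrogen is the whole change. With no readable size to carry over, nothing beyond the scatter is expected in this assay and no direction can be given, so the estimate is a step that the limit leaves unreadable from compound 2 to compound 3 and no more. For compound 3 the expected value is 30 h with an estimated range from 18 h to 50 h in this read-out.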

Compound 3, half-life: > 24 h
Compound 3: only a limit was reported; the forecaster's own chance of this, stated with the estimate: 80%; the middle value does not contradict the limit.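

No step among compound 1, compound 2 and compound 3 can be read, because each value is only a limit: the limit of > 24 h in this assay, at which 3 of the 3 values shown sit.

On these data alone, how long each compound actually lasts, and whether phenyl, 3-chloro-2-fluorophenyl and 4-fluorophenyl differ at all in this assay, stays open.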